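Swapping a thiophene for a dimethylpyridine: expected cell tolerance

The source may report more compounds than this note shows. Statements on the series, on what has been measured and on what is new or still open speak of the compounds shown alone.

Measured so far:
- compound 1, `Cc1cnc(Nc2ccc(C#N)cc2)nc1Nc1c(F)cc(-c2ccoc2)cc1F`: 4200 nM
- compound 2, `Cc1cnc(Nc2ccc(C#N)cc2)nc1Nc1c(F)cc(-c2cccs2)cc1F`: 8000 nM
- compound 3, `Cc1cc(-c2cccs2)cc(C)c1Nc1ccnc(Nc2ccc(C#N)cc2)n1`: 10000 nM

The three compounds were tested in a toxicity assay on MT4 cells (Homo sapiens) for cytotoxicity, read by MTT assay, with a stated time of 5 days; a lower number here means that less compound is tolerated, a higher number that more compound is tolerated. Compound 3 gives the highest of the three numbers in this assay; its gap to compound 2 is within the scatter, so those two cannot be told apart, while its gap to compound 1 lies beyond the scatter. Among the compounds with values here, the only step between compounds that differ in one place, a 1.9-fold higher number from compound 1 to compound 2 (0.28 log units; within the scatter), is itself within the scatter.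

Compound 4, `Cc1cc(-c2cc(C)c(Nc3ccnc(Nc4ccc(C#N)cc4)n3)c(C)c2)cc(C)n1`, differs from compound 3 by 2,6-dimethylpyridin-4-yl in place of thiophen-2-yl on an aromatic carbon. No measured step covers this exchange: the one step shown replaces one five-membered aromatic ring by another, whereas here a six-membered ring with one nitrogen enters. Within the data shown here, with no step pointing either way, the expectation is a change of at most the scatter, in no set direction.

Compound 4 is therefore expected to give about 11000 nM in this assay, within 5000 nM to 30000 nM, which means an expected step of a 1.1-fold higher number from compound 3 to compound 4 (0.04 log units; within the scatter).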

Compound 4, half-maximal cytotoxic concentration: 2300 nM
Compound 4: middle estimate off by 4.8-fold (0.68 log units), on the high side; measured number outside the range, below it.
By their numbers in this assay, from the lowest: compounds 4, 1, 2 and 3 (each within the scatter of the next, the first and the last beyond it).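

In this assay, the position that carries thiophen-2-yl in compound 3 turns out not to be indifferent: putting 2,6-dimethylpyridin-4-yl there gives a 4.3-fold lower number from compound 3 to compound 4 (0.64 log units; beyond the scatter). The earlier exchange of one five-membered aromatic ring for another stayed within the scatter, whereas this exchange to a six-membered aromatic ring, with 8 heavy atoms in place of 5 and the same counts of hydrogen-bond donors and acceptors, lowers the amount of compound the cells tolerate. Nothing measured here identifies which feature of the new group accounts for this step.

The compounds shown leave open whether the step follows the ring nitrogen or the two methyl groups on the pyridine. A plain phenyl ring or an unsubstituted pyridin-4-yl at this position would help to separate the two.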